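A few compounds are considered here, and "the series" means these few. Any claim that something is new, unique, unknown or untested is made for them only; others in the source may bear on it.

Three measured analogues share a hydrazone-linked thiazole scaffold. Compound 1 `C/C(=N/Nc1nc(-c2ccc(C#N)cc2)cs1)c1ccco1` gives 40% in an in vitro assay on BTI-TN-5B1-4 cells for inhibition of Amine oxidase [flavin-containing] A (Homo sapiens), read by Amplex Red, with a stated time of 15 min, tested at 100 uM; a lower number here means less inhibition, a higher number more inhibition at the concentration tested (going by the name of the read-out). Compound 2 `C/C(=N/Nc1nc(-c2ccc(C#N)cc2)cs1)c1cccs1` gives 40% in this assay. Compound 3 `C/C(=N/Nc1nc(-c2ccc(F)cc2F)cs1)c1ccco1` gives 40% in this assay. For the measured compounds named here, the only single-point change measured so far, (thiophen-2-yl in place of furan-2-yl on a carbon with a double bond to nitrogen), produced no change at the digits printed from compound 1 to compound 2 (within the scatter). The difference between the cores of compound 1 and compound 3 is not broken down here; their values are level within the scatter.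

Compound 4 `C/C(=N/Nc1nc(-c2ccc(F)cc2F)cs1)c1cccs1` is not yet measured in this assay. It differs from compound 3 by thiophen-2-yl in place of furan-2-yl on a carbon with a double bond to nitrogen, the same change as that from compound 1 to compound 2. Since that earlier change gave no change at the digits printed from compound 1 to compound 2 (within the scatter), the step from compound 3 to compound 4 is expected to be no change at the digits printed from compound 3 to compound 4 (within the scatter). Compound 4 is therefore estimated at 40%, with a range of 27% to 53%.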

Compound 4, a percentage reported as inhibition, at one concentration (the size of the read-out at that concentration, not a potency): 40%
For compound 4 middle estimate and measured number coincide at the digits printed; the range from low to high includes it.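

In this assay, thiophen-2-yl in place of furan-2-yl on a carbon with a double bond to nitrogen gives no change at the digits printed from compound 3 to compound 4 (within the scatter), and the step matches the earlier one on the other core: the same change on two cores in this assay, no change at the digits printed (within the scatter) from compound 1 to compound 2 and no change at the digits printed (within the scatter) from compound 3 to compound 4, 0 percentage points apart, within the scatter of two such steps

On these two cores, then, the swap carries over with no step beyond the scatter. Since both steps are null and come from a single concentration, this does not show that a change with a real effect would carry over, nor does it extend to other cores.

Open, as far as these compounds go, is whether an amine or a carboxylic acid in place of the five-membered ring would shift the inhibition on either core. Also open, from the compounds shown here alone, is what a longer chain would do in place of the saturated chain carbon.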